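From compound 3 to compound 4: a step hidden by limits

A few compounds are considered here, and "the series" means these few. Any claim that something is new, unique, unknown or untested is made for them only; others in the source may bear on it.

- Compound 1 `N#Cc1cn(COC(CO)CO)c2ncnc(N)c12`: > 320000 nM (a limit)
- Compound 2 `NC(=O)c1cn(COC(CO)CO)c2ncnc(N)c12`: > 320000 nM (a limit)
- Compound 3 `N/C(=N\O)c1cn(COC(CO)CO)c2ncnc(N)c12`: > 100000 nM (a limit)

In an ADME assay on HFF cells (Homo sapiens) for cytotoxicity (a lower number here means a stronger inhibitor, a higher number a weaker inhibitor), compound 3 gives > 100000 nM, which is a limit and not a number. The other two values are limits as well. Compound 4 `NC(=S)c1cn(COC(CO)CO)c2ncnc(N)c12` differs from it on an aromatic carbon: a group of 3 heavy atoms (1 carbon, 1 nitrogen, 1 sulfur; no ring) in place of a group of 4 heavy atoms (1 carbon, 2 nitrogen, 1 oxygen; no ring), on an aromatic carbon. Three measured steps made changes on an aromatic carbon: a step that the two limits leave unreadable from compound 1 to compound 2, a step that the two limits leave unreadable from compound 1 to compound 3 and a step that the two limits leave unreadable from compound 2 to compound 3. None of them has a readable size, so they offer no measured size to carry over, and no change beyond the scatter is expected. The expected step is a step that the limit leaves unreadable from compound 3 to compound 4. Compound 4 is estimated at 150000 nM, with an expected range from 50000 nM to 320000 nM.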

Compound 4, half-maximal inhibitory concentration: > 100000 nM
Compound 4: only a limit was reported; the forecaster's own chance of this, stated with the estimate: 75%; the middle value does not contradict the limit.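

In this assay compound 4 gives > 100000 nM, which is a limit and not a number; its steps from compound 1, compound 2 and compound 3 cannot be read. The compounds shown leave open whether these four differ at all in this assay.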